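The source may hold more compounds than are shown below. What is called first, only, known or untested is meant among the compounds shown, and "the series" means these compounds.

Compound 1 `O=C(Nc1ccc(-n2ccc3nc(C(=O)NCc4ccccc4)ccc32)cc1)Nc1ccc(Cl)c(C(F)(F)F)c1` and compound 3 `O=C(Nc1ccc(-n2ccc3nc(C(=O)NCc4ccccc4)ccc32)cc1)c1ccc(Cl)c(C(F)(F)F)c1` share one core and differ in that (4-chloro-3-(trifluoromethyl)phenyl in place of (4-chloro-3-(trifluoromethyl)phenyl)amino on a carbonyl carbon); in an ADME assay on HS27 cells (Homo sapiens) for cytotoxicity, read by MTT assay (on this read-out lower numbers stand for stronger inhibition and higher numbers for weaker inhibition), compound 1 gives 3000 nM and compound 3 gives 1500 nM, so a 2.0-fold lower number from compound 1 to compound 3 (0.30 log units; within the scatter). Compound 2 `O=C(Nc1ccc(-n2ccc3nc(C(=O)NCc4ccccc4)ccc32)cc1)Nc1cccc(C(F)(F)F)c1` arises from compound 1 by the change (hydrogen in place of chloro on an aromatic carbon), and in this assay compound 2 gives only a limit, > 10000 nM. That change made an at least 3.3-fold higher number from compound 1 to compound 2 (0.52 log units; beyond the scatter). Compound 4 `O=C(Nc1ccc(-n2ccc3nc(C(=O)NCc4ccccc4)ccc32)cc1)c1cccc(C(F)(F)F)c1` arises from compound 3 by the same change, (hydrogen in place of chloro on an aromatic carbon), at a place described in the same words. For compound 4 a step of a 4.0-fold higher number from compound 3 to compound 4 (0.60 log units; beyond the scatter) is expected, because the earlier step of an at least 3.3-fold higher number from compound 1 to compound 2 (0.52 log units; beyond the scatter) went the same way. Compound 4 is thus estimated at 6000 nM, with a real chance that only a limit is seen.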

Compound 4, half-maximal inhibitory concentration: > 10000 nM
Compound 4 was reported as a limit; the forecaster's own chance of this, stated with the estimate: 40%; at least 1.6-fold (0.22 log units) between middle value and limit.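

In this assay, hydrogen in place of chloro moved the number the same way on both cores, giving an at least 6.6-fold higher number from compound 3 to compound 4 (0.82 log units; beyond the scatter). Another listed step, an at least 3.3-fold higher number from compound 1 to compound 4 (0.52 log units; beyond the scatter), also ends at a higher number, while the step between the two compounds reported only as limits cannot be read. So the direction of this change carried over between these two cores, but not a measured size, and whether the change has a larger effect on one core than the other remains unknown: the same change on two cores in this assay, an at least 3.3-fold higher number (0.52 log units; beyond the scatter) from compound 1 to compound 2 and an at least 6.6-fold higher number (0.82 log units; beyond the scatter) from compound 3 to compound 4; the limit leaves it open whether they differ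

The compounds shown carry only chloro or hydrogen at this place on the ring. On these data alone, how a fluoro, methyl or methoxy group there would read remains open, as does whether the step holds on any other core.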